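This account rests on a few compounds, and the source may have more. Where it says the series, first, only, none or still open, it means among the compounds named here.

Measured so far:
Compound 1 `Cc1ccc(/C=C2\CN(C(=S)SCc3cn(Cc4ccccc4Cl)nn3)C/C(=C\c3ccc(C)cc3)C2=O)cc1` gives 93200 nM in a functional assay on MDA-MB-231 cells (Homo sapiens) for cytotoxicity, read by MTT assay, with a stated time of 24 h; on this read-out higher numbers stand for weaker inhibition and lower numbers for stronger inhibition.
Compound 2 `Cc1ccc(/C=C2\CN(Cc3cn(Cc4ccccc4F)nn3)C/C(=C\c3ccc(C)cc3)C2=O)cc1` gives 10000 nM in this assay.
Compound 3 `Cc1ccc(/C=C2\CN(Cc3cn(Cc4ccc(F)cc4)nn3)C/C(=C\c3ccc(C)cc3)C2=O)cc1` gives 26800 nM in this assay.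

Compound 1 stands highest of the three, beyond the scatter from both compound 2 and compound 3. Compound 4 `Cc1ccc(/C=C2\CN(C(=S)SCc3cn(Cc4ccc(F)cc4)nn3)C/C(=C\c3ccc(C)cc3)C2=O)cc1` differs from compound 1 in one place: 4-fluorophenyl in place of 2-chlorophenyl on a saturated chain carbon bound to an aromatic nitrogen. Among the compounds with values here, only one measured step bears on it, a 2.7-fold higher number from compound 2 to compound 3 (0.43 log units; beyond the scatter), which shifted a fluorine from the 2-position to the 4-position on a saturated chain carbon bound to an aromatic nitrogen and gave a modest rise, though compounds 2 and 3 differ from compounds 1 and 4 elsewhere too, and here the halogen itself changes. A modest rise or no step beyond the scatter is therefore expected, a 1.4-fold higher number from compound 1 to compound 4 (0.14 log units; within the scatter). Compound 4 is estimated at 130000 nM, within 45000 nM to 350000 nM.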

Compound 4, half-maximal inhibitory concentration: 45600 nM
For compound 4 the middle estimate is 2.9-fold (0.45 log units) above the measured one; low and high end bracket the measured number.
By their numbers in this assay, from the lowest: compound 2; then compounds 3 and 4 (each within the scatter of the next); then compound 1.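

Replacing 2-chlorophenyl with 4-fluorophenyl gives a 2.0-fold lower number from compound 1 to compound 4 (0.31 log units; beyond the scatter) in this assay, showing that a change at this place, on a saturated chain carbon bound to an aromatic nitrogen, can also lower the number. The direction is opposite to a 2.7-fold higher number from compound 2 to compound 3 (0.43 log units; beyond the scatter), but that pair has a different core and only moves the fluorine, whereas here the halogen changes too. No measurement here explains this step.

Still open, going by these compounds, is whether the halogen or its place matters more; 2-fluorophenyl and 4-chlorophenyl on the core of compound 1 would separate them. On these data alone, how a phenyl ring carrying an amine or a carboxylic acid would read also remains open.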